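Replacing the Urea Tail of Compound 1 with Hydroxyphenyl

The source may hold more compounds than are shown below. What is called first, only, known or untested is meant among the compounds shown, and "the series" means these compounds.

Compound 1, `COc1cc(NC(C)CCCNC(=O)NNC(=O)Nc2ccc(F)cc2)c2ncccc2c1`: in a functional assay on MIA PaCa-2 cells (Homo sapiens) for inhibition, read by MTT assay, with a stated time of 72 h (on this read-out higher numbers stand for weaker inhibition and lower numbers for stronger inhibition), compound 1 gives >= 250000 nM, which is a limit of the assay and not a number.
Compound 2, `COc1cc(NC(C)CCCNC(=O)Nc2cccc(C(F)(F)F)c2)c2ncccc2c1`: in this assay compound 2 gives 17000 nM.

Compound 1 therefore stands only at a limit, with no fixed number of its own; the limit of >= 250000 nM in this assay, at which 1 of the 2 values shown sits, is the single such limit among the two values shown. The change to compound 3, `COc1cc(NC(C)CCCNC(=O)Nc2ccc(O)cc2)c2ncccc2c1`, is 4-hydroxyphenyl in place of ((4-fluorophenyl)carbamoyl)amino on an amide-type nitrogen. Among the compounds with values here, the one measured step that bears on it is an at least 14-fold lower number from compound 1 to compound 2 (1.16 log units; beyond the scatter), where the same group left the amide-type nitrogen and 3-(trifluoromethyl)phenyl entered. On that basis a step in the same direction, towards a lower number, is expected for compound 3, although its size remains uncertain. Compound 3 is estimated at 30000 nM, within a range from 8000 nM to 150000 nM. This estimate corresponds to an expected step of an at least 8.3-fold lower number from compound 1 to compound 3 (0.92 log units; beyond the scatter), which would lie beyond the scatter.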

Compound 3, half-maximal inhibitory concentration: 57000 nM
The estimate for compound 3 lay 1.9-fold (0.28 log units) below the measured number; the range from low to high includes it.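

In this assay, 4-hydroxyphenyl on the amide-type nitrogen also gives a clear gain over the ((4-fluorophenyl)carbamoyl)amino group, with an at least 4.3-fold lower number from compound 1 to compound 3 (0.64 log units; beyond the scatter), so the drop is not confined to 3-(trifluoromethyl)phenyl. The two replacements are not interchangeable, however: exchanging 3-(trifluoromethyl)phenyl for 4-hydroxyphenyl gives a 3.4-fold higher number from compound 2 to compound 3 (0.53 log units; beyond the scatter). Within the data shown here, this is the first comparison at this position between two groups with measured numbers, so the choice of ring substituent is seen to matter here.

Compound 1 stands at a limit and not at a number, so the full size of its steps stays open: the limit of >= 250000 nM in this assay, at which 1 of the 3 values shown sits. The compounds shown also do not tell whether the gap between compound 2 and compound 3 follows the substituent or its place on the ring, which 3-hydroxyphenyl or 4-(trifluoromethyl)phenyl on the same nitrogen would address.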